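Methylphenyl to Fluorophenyl on the Aromatic Nitrogen

The compounds below may be only part of what the source reports. "The series", "measured", "known", "first", "only" and "open" are said of these compounds alone.

Compound 3 `Cc1cccc(-n2cc(-c3ccc(NS(=O)(=O)c4c[nH]c(=O)[nH]c4=O)cc3)nn2)c1` gives 7490 nM in a functional assay on OVCAR-3 cells (Homo sapiens) for antiproliferative activity, read by MTT assay, with a stated time of 24 h (a lower number here means a stronger inhibitor, a higher number a weaker inhibitor), the highest of the two numbers, while compound 1 `Cc1ccccc1-n1cc(-c2ccccc2NS(=O)(=O)c2c[nH]c(=O)[nH]c2=O)nn1` gives 6550 nM, a difference within the scatter. Compound 2 `O=c1[nH]cc(S(=O)(=O)Nc2ccccc2-c2cn(-c3ccc(F)cc3)nn2)c(=O)[nH]1` reaches only a limit of this assay, > 20000 nM, which is the limit of > 20000 nM in this assay, at which 1 of the 3 values shown sits. Compound 4 `O=c1[nH]cc(S(=O)(=O)Nc2ccc(-c3cn(-c4ccccc4F)nn3)cc2)c(=O)[nH]1` differs from compound 3 by 2-fluorophenyl in place of 3-methylphenyl on an aromatic nitrogen. Going by the values given here, the one measured step that resembles this change, an at least 3.0-fold higher number from compound 1 to compound 2 (0.48 log units; beyond the scatter), also put a fluorophenyl where a methylphenyl stood on that nitrogen, and the number rose to a limit. A weakening of comparable size is therefore expected here, a 2.1-fold higher number from compound 3 to compound 4 (0.33 log units; beyond the scatter), with a real chance that only a limit is reported. Compound 4 is estimated at 16000 nM, within 6000 nM to 45000 nM.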

Compound 4, half-maximal inhibitory concentration: 8030 nM
Compound 4: the middle estimate sits 2.0-fold (0.30 log units) above what was measured; measured number inside the range.
By their numbers in this assay, from the lowest: compounds 1, 3 and 4 (each within the scatter of the next). At a limit, above all of these: compound 2.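

On the aromatic nitrogen, 2-fluorophenyl in place of 3-methylphenyl gives a 1.1-fold higher number from compound 3 to compound 4 (0.03 log units; within the scatter) in this assay, so a fluorophenyl at this position does not by itself bring a loss of activity. Compounds 2 and 4 differ in more than one place, so this step cannot be set directly against the earlier one. Compound 2 remains alone at a limit: the limit of > 20000 nM in this assay, at which 1 of the 4 values shown sits.

Still open, going by these compounds, is whether 4-fluorophenyl would behave like 2-fluorophenyl on the core of compound 3. On these data alone, the effect of a phenyl carrying an amine or a carboxylic acid on this nitrogen is also open.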